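The compounds below may be only part of what the source reports. "The series", "measured", "known", "first", "only" and "open" are said of these compounds alone.

Measured compounds:
compound 1 `CN(C)CCNc1cc2c(cn1)cc(NC(=O)c1ccncc1)c(=O)n2C`, 36600 nM
compound 2 `COc1cc(C(=O)Nc2cc3cnc(NCCN(C)C)cc3n(C)c2=O)cc(OC)c1OC`, 21500 nM

Both were run in a functional assay on MCF7 cells (Homo sapiens) for antiproliferative activity, read by MTT assay, with a stated time of 48 h; on this read-out higher numbers stand for weaker inhibition and lower numbers for stronger inhibition. Compound 1 gives 36600 nM, the highest of the two numbers; compound 2 gives 21500 nM, and the gap between them lies within the scatter, so the two values say nothing about order. Compound 3 `COc1ccc(C(=O)Nc2cc3cnc(NCCN(C)C)cc3n(C)c2=O)cc1` is not yet measured. Relative to compound 1 it differs at a single place: 4-methoxyphenyl in place of pyridin-4-yl on a carbonyl carbon. Compound 2, which gives 21500 nM, already carries a phenyl ring bearing methoxy groups on the same carbonyl carbon and sits within the scatter of compound 1, so no step beyond the scatter is expected for this change in this assay, a slightly lower number at most. The estimated step of a 1.4-fold lower number from compound 1 to compound 3 (0.15 log units; within the scatter) is expected to remain within the scatter. For compound 3 the expected value in this assay is 26000 nM, with a range from 9000 nM to 75000 nM.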

Compound 3, half-maximal inhibitory concentration: 37300 nM
Compound 3: middle estimate off by 1.4-fold (0.16 log units), on the low side; the measured number falls inside the stated range.
By their numbers in this assay, from the lowest: compounds 2, 1 and 3 (each within the scatter of the next).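

In this assay, for the compounds shown here, 4-methoxyphenyl in place of pyridin-4-yl on a carbonyl carbon gives a 1.0-fold higher number from compound 1 to compound 3 (0.01 log units; within the scatter), the first direct reading of this exchange at this position. For this pair, the ring of carbon only carrying methoxy and the ring with one hetero atom cannot be told apart on this read-out, and a nitrogen in the ring is not needed to reach the value of compound 1. No measurement is at hand that could explain why the two rings read alike.

Every compound shown has a six-membered aromatic ring on this carbonyl carbon, so it remains open whether a non-aromatic group there, such as a short alkyl chain, a primary amine or a carboxylic acid, would separate from these values. On these data alone, the effect of changes elsewhere on the shared core also remains open.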